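Adding a Second Chloro: An Expected Cytotoxicity Reading

The source may hold more compounds than are shown below. What is called first, only, known or untested is meant among the compounds shown, and "the series" means these compounds.

Compound 1 `O=[N+]([O-])c1cc(CSc2nnc(-c3ccccc3)n2Cc2ccccc2)cc([N+](=O)[O-])c1` and compound 2 `O=[N+]([O-])c1cc(CSc2nnc(-c3ccc(Cl)cc3)n2Cc2ccccc2)cc([N+](=O)[O-])c1` share one core and differ only by chloro in place of hydrogen on an aromatic carbon. In an ADME assay on A-431 cells (Homo sapiens) for cytotoxicity, with a stated time of 48 h (a higher number here means a weaker inhibitor, a lower number a stronger inhibitor), compound 1 gives > 30000 nM, which is a limit of the assay rather than a measured number. In this assay compound 2 gives > 30000 nM, again a limit and not a number. The change between them is therefore a step that the two limits leave unreadable from compound 1 to compound 2.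

Compound 3 `Cn1c(SCc2ccc(Cl)cc2)nnc1-c1cc([N+](=O)[O-])cc([N+](=O)[O-])c1` is built on a different core; the difference between the two cores is not broken down here. In this assay compound 3 gives > 30000 nM, once more a limit. Taken together, the picture so far is the limit of > 30000 nM in this assay, at which 3 of the 3 values shown sit.

Compound 4 `Cn1c(SCc2ccc(Cl)c(Cl)c2)nnc1-c1cc([N+](=O)[O-])cc([N+](=O)[O-])c1` has not yet been measured. It differs from compound 3 by chloro in place of hydrogen on an aromatic carbon. For the measured compounds named here, this is the same kind of change as the one from compound 1 to compound 2, though the surroundings are not identical: in compound 2 the entering chloro sits para to a large group, whereas in compound 4 it sits ortho to a chloro group and meta to a large group.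

Because every reading here is the limit of > 30000 nM in this assay, at which 3 of the 3 values shown sit, the earlier step offers no measurable size to carry over. For compound 4 the expected step is a step that the limit leaves unreadable from compound 3 to compound 4. Compound 4 is therefore expected to give 40000 nM, most likely again reported only as a limit, with a plausible range from 15000 nM to 100000 nM.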

Compound 4, half-maximal inhibitory concentration: > 30000 nM
Compound 4 was reported as a limit; the forecaster's own chance of this, stated with the estimate: 80%; the middle value does not contradict the limit.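

No size can be read for the change from compound 3 to compound 4, since in this assay both readings are limits of the assay and not numbers. The whole set now sits at one reading: the limit of > 30000 nM in this assay, at which 4 of the 4 values shown sit.

The compounds shown leave open whether adding a chloro changes the cytotoxicity of compound 1 or compound 3 at all, and how large any such change would be.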